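This account rests on a few compounds, and the source may have more. Where it says the series, first, only, none or still open, it means among the compounds named here.

In a functional assay on A549 cells (Homo sapiens) for inhibition, read by MTT assay, with a stated time of 48 h (a higher number here means a weaker inhibitor, a lower number a stronger inhibitor), compound 1 (`COc1ccc2c(=O)c(/C=C/C(=O)Nc3cccc(Cl)c3)coc2c1`) gives 470 nM while compound 2 (`COc1ccc2c(=O)c(/C=C/C(=O)Nc3ccccc3C)coc2c1`) gives 23400 nM as the higher of the two numbers. Compound 3 (`CCOc1ccc(NC(=O)/C=C/c2coc3cc(OC)ccc3c2=O)cc1`) carries 4-ethoxyphenyl in place of 2-methylphenyl on an amide-type nitrogen. Going by the values given here, the one measured step at that nitrogen (a 50-fold higher number from compound 1 to compound 2 (1.70 log units; beyond the scatter)) is large, and it leaves compound 2 at the weak end of a short record. In this assay the expected step (a 7.8-fold lower number from compound 2 to compound 3 (0.89 log units; beyond the scatter)) is sizeable and smaller than that one. The estimate for compound 3 is 3000 nM with an expected range of 400 nM to 20000 nM in this series.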

Compound 3, half-maximal inhibitory concentration: > 100000 nM
Compound 3: only a limit was reported (the forecaster's own chance of this, stated with the estimate: 5%); middle value at least 33-fold (1.52 log units) from the limit.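

Compound 3 gives only a limit of the assay, not a number: the limit of > 100000 nM in this assay, at which 1 of the 3 values shown sits. The group on the amide-type nitrogen now spans more than compound 2 showed, with an at least 4.2-fold higher number from compound 2 to compound 3 (0.63 log units; beyond the scatter) and an at least 210-fold higher number from compound 1 to compound 3 (2.32 log units; beyond the scatter). Going by these compounds alone, both steps are lower bounds, and 4-ethoxyphenyl, the only one of the three groups with a hydrogen-bond acceptor, gives no measurable gain over 2-methylphenyl.

Among 3-chlorophenyl, 2-methylphenyl and 4-ethoxyphenyl, the substituent and its place on the ring change together, and the two effects stay unseparated. A 4-chlorophenyl or 3-methoxyphenyl group on the same nitrogen would begin to pull them apart.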